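Swapping a Fluorinated Ring for a Methylated One

A few compounds are considered here, and "the series" means these few. Any claim that something is new, unique, unknown or untested is made for them only; others in the source may bear on it.

Of the compounds shown here, three sharing one core have been measured in an assay on mitochondria from L6 cells (Rattus norvegicus) for activation, with a stated time of 90 min; a higher number here means that more compound is needed for the effect, a lower number that less compound is needed. Compound 1 `Fc1ccccc1Nc1nc2nonc2nc1Nc1ccccc1` gives 2200 nM, compound 2 `Fc1cccc(Nc2nc3nonc3nc2Nc2ccccc2F)c1` gives 190 nM, and compound 3 `Fc1ccccc1Nc1nc2nonc2nc1Nc1cccc(F)c1F` gives 500 nM. On these numbers compound 3 stands second highest of the three: compound 2 lies closest, with a 2.6-fold higher number from compound 2 to compound 3 (0.42 log units; beyond the scatter), while compound 1 lies furthest, with a 4.4-fold lower number from compound 1 to compound 3 (0.64 log units; beyond the scatter).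

Compound 4 `Cc1ccccc1Nc1nc2nonc2nc1Nc1ccccc1F` has not yet been measured in this assay. Its difference from compound 3 is 2-methylphenyl in place of 2,3-difluorophenyl on a nitrogen on an aromatic ring.

Among the measured compounds shown here, two measured steps bear on this change. The step of a 4.4-fold lower number from compound 1 to compound 3 (0.64 log units; beyond the scatter) shows what placing two fluorines on this ring does; the step of a 12-fold lower number from compound 1 to compound 2 (1.06 log units; beyond the scatter) shows that a single fluorine on the ring can do even more. For the measured compounds named here, compound 4 removes both fluorines and introduces a methyl group instead, a group for which no measured step exists here, so the direction is uncertain. Because the fluorine-bearing compounds were helped relative to compound 1 2200 nM, the expectation for compound 4 is a modest rise in number, a 2.0-fold higher number from compound 3 to compound 4 (0.30 log units; within the scatter), with a wide range. Compound 4 is therefore estimated at 1000 nM, between 300 nM and 4000 nM.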

Compound 4, half-maximal effective concentration: 1100 nM
Estimate against measurement, compound 4: 1.1-fold (0.04 log units) below, within the range that was stated.
By their numbers in this assay, from the lowest: compound 2; then compound 3; then compounds 4 and 1 (each within the scatter of the next).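

In this assay, adding a methyl group to the phenyl ring of compound 1 gives a 2.0-fold lower number from compound 1 to compound 4 (0.30 log units; within the scatter), so this methyl group cannot be told apart from hydrogen on the strength of these numbers. The fluorinated compounds, by contrast, stay clearly ahead of the methylated one, with a 2.2-fold higher number from compound 3 to compound 4 (0.34 log units; beyond the scatter) and a 5.8-fold higher number from compound 2 to compound 4 (0.76 log units; beyond the scatter); among these four compounds, then, a change on this ring does not lower the number merely by adding a group, and only the fluorine-bearing rings do so beyond the scatter. Nothing available here explains why the methyl and fluorine compounds differ.

On these data alone, what remains open is whether this behaviour is special to fluorine or would also appear with other groups on the same ring, such as chloro, methoxy or an amine. As far as these compounds go, it is also open whether a larger alkyl group, such as ethyl or isopropyl, would stay level with compound 1, as the methyl group does, or would shift the number in either direction.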